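The source may hold more compounds than are shown below. What is called first, only, known or untested is meant among the compounds shown, and "the series" means these compounds.

Measured compounds:

compound 1, `CCCNCc1cc(-c2c(C(=O)NCC)noc2-c2cc(C(C)C)c(O)cc2O)on1`: 117 nM
compound 2, `CCNC(=O)c1noc(-c2cc(C(C)C)c(O)cc2O)c1-c1cc(C(=O)NC)no1`: 124 nM
compound 3, `CCNC(=O)c1noc(-c2cc(C(C)C)c(O)cc2O)c1-c1ccn(CC)n1`: 25 nM

In a functional assay on HCT-116 cells (Homo sapiens) for inhibition (a higher number here means a weaker inhibitor, a lower number a stronger inhibitor), compound 1 stands at the second highest number of the three; compound 2 is nearest, a step of a 1.1-fold higher number from compound 1 to compound 2 (0.03 log units; within the scatter), within the scatter, while compound 3 is furthest, a step of a 4.7-fold lower number from compound 1 to compound 3 (0.67 log units; beyond the scatter).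

Compound 4, `CCNC(=O)c1noc(-c2cc(C(C)C)c(O)cc2O)c1-c1cnn(C)c1`, has not yet been measured. It differs from compound 1 in one place: 1-methyl-1H-pyrazol-4-yl in place of 3-((propylamino)methyl)-1,2-oxazol-5-yl on an aromatic carbon.

Going by the values given here, two measured steps bear on this change. Going from compound 1 to compound 3, where a pyrazole replaces the isoxazole, the number fell by a 4.7-fold lower number from compound 1 to compound 3 (0.67 log units; beyond the scatter); from compound 2 to compound 3 the corresponding fall was a 5.0-fold lower number from compound 2 to compound 3 (0.70 log units; beyond the scatter). The step to compound 4 also exchanges the isoxazole for a pyrazole, though with a methyl rather than an ethyl and a different point of attachment, so a lower number than compound 1 is expected, in a similar direction but with less certainty about size. Compound 4 is therefore expected to give 55 nM, within 20 nM to 150 nM, a step of a 2.1-fold lower number from compound 1 to compound 4 (0.33 log units; beyond the scatter).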

Compound 4, half-maximal inhibitory concentration: 41 nM
Estimate against measurement, compound 4: 1.3-fold (0.13 log units) above; measured number inside the range.
By their numbers in this assay, from the lowest: compounds 3 and 4 (each within the scatter of the next); then compounds 1 and 2 (each within the scatter of the next).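

In this assay, the 1-methyl-1H-pyrazol-4-yl group also gives a lower number than either substituted 1,2-oxazol-5-yl group, with a 2.9-fold lower number from compound 1 to compound 4 (0.46 log units; beyond the scatter) and a 3.0-fold lower number from compound 2 to compound 4 (0.48 log units; beyond the scatter), so the fall seen with compound 3 is not confined to a single pyrazole. Between the two pyrazoles there is a 1.6-fold higher number from compound 3 to compound 4 (0.21 log units; within the scatter), which lies within the scatter, so this position shows no readable difference between 1-ethyl-1H-pyrazol-3-yl and 1-methyl-1H-pyrazol-4-yl. Nothing measured here speaks to the reason for these steps.

The compounds shown leave open whether the lower numbers follow from the pyrazole ring itself or from the absence of the propylaminomethyl and methylcarbamoyl side groups. A plain 1,2-oxazol-5-yl group, or a pyrazole carrying an amine or a longer chain on its nitrogen, could separate these two readings.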